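Shortening a selenium chain on the shared core

This account rests on a few compounds, and the source may have more. Where it says the series, first, only, none or still open, it means among the compounds named here.

The compounds measured in a functional assay on RKO cells (Homo sapiens) for inhibition, read by MTT assay, with a stated time of 48 h (on this read-out lower numbers stand for stronger inhibition and higher numbers for weaker inhibition), are these.
Compound 1 (`COc1ccc(N(C)c2nc(C)nc3ccccc23)cc1C(=O)OCCC[Se]C#N`) gives 1140 nM
Compound 2 (`COc1ccc(N(C)c2nc(C)nc3ccccc23)cc1[Se]C`) gives 11 nM
Compound 3 (`COc1ccc(N(C)c2nc(C)nc3ccccc23)cc1OCCCC[Se]C#N`) gives 1360 nM

Compound 3 at 1360 nM stands within the scatter of compound 1 at 1140 nM and far above compound 2 at 11 nM on this read-out. The next structure, compound 4 (`COc1ccc(N(C)c2nc(C)nc3ccccc23)cc1C[Se]C#N`), alters compound 3 in one place: a group of 4 heavy atoms (2 carbon, 1 nitrogen, 1 selenium; no ring) in place of a group of 8 heavy atoms (5 carbon, 1 nitrogen, 1 oxygen, 1 selenium; no ring), on an aromatic carbon with the new group ortho to a methoxy group and meta to a large group.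

Within the data shown here, three measured steps bear on this change. There is a 100-fold lower number from compound 1 to compound 2 (2.02 log units; beyond the scatter) and also a 120-fold higher number from compound 2 to compound 3 (2.09 log units; beyond the scatter) and both are large, whereas a 1.2-fold higher number from compound 1 to compound 3 (0.08 log units; within the scatter) stays within the scatter. The two long groups therefore sit level, and the much smaller group without a triple bond gives the far lower number. Among the measured compounds shown here, compound 4 sheds much of the chain yet keeps the triple bond, and no measured compound tests that combination. Compound 2 at 11 nM marks the low end seen so far, so a sizeable drop in this assay is expected for compound 4, though probably not the full distance. The expected move is a 14-fold lower number from compound 3 to compound 4 (1.13 log units; beyond the scatter) and its size is uncertain. Compound 4 is estimated at 100 nM with an expected range from 15 nM to 800 nM in this test.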

Compound 4, half-maximal inhibitory concentration: 316 nM
For compound 4 the middle estimate is 3.2-fold (0.50 log units) below the measured one; measured number inside the range.
By their numbers in this assay, from the lowest: compound 2; then compound 4; then compounds 1 and 3 (each within the scatter of the next).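

In this assay, cutting the chain on this aromatic carbon, ortho to a methoxy group, lowers the number even though the nitrile stays, with a 4.3-fold lower number from compound 3 to compound 4 (0.63 log units; beyond the scatter) and, starting from the ester-bearing chain, a 3.6-fold lower number from compound 1 to compound 4 (0.56 log units; beyond the scatter) as the two modest steps. The shorter chain covers only part of the distance to the low end, since a 29-fold higher number from compound 2 to compound 4 (1.46 log units; beyond the scatter) still stands as a large step. Both groups in that last step are short, so among these compounds a short chain does not by itself give the lowest number: a group of 4 heavy atoms with a triple bond sits well above a group of 2 heavy atoms without one.

No measured evidence on why these numbers differ accompanies the compounds. The compounds shown leave open whether the nitrile or the carbon linking selenium to the ring carries the remaining gap, which a methyl on selenium kept on that linking carbon or a nitrile on selenium attached directly to the ring would separate, and what an amine or a carboxylic acid would do at this place also stays open.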